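A few compounds are considered here, and "the series" means these few. Any claim that something is new, unique, unknown or untested is made for them only; others in the source may bear on it.

Measured compounds in a functional assay for inhibition, with Homo sapiens as the target; on this read-out higher numbers stand for weaker inhibition and lower numbers for stronger inhibition:
compound 1 `Cc1cccc(Nc2nccc(-c3cccs3)n2)c1` gives 300 nM
compound 2 `c1cc(Nc2nccc(-c3cccs3)n2)cc(OCCn2ccnc2)c1` gives 100 nM
compound 3 `CN(C)c1cccc(Nc2nccc(-c3cccs3)n2)c1` gives 2400 nM

Compound 1 stands second highest of the three numbers in this assay. Its nearest neighbour is compound 2, reached by a 3.0-fold lower number from compound 1 to compound 2 (0.48 log units; beyond the scatter), and its furthest is compound 3, reached by an 8.0-fold higher number from compound 1 to compound 3 (0.90 log units; beyond the scatter). Between those two, a 24-fold higher number from compound 2 to compound 3 (1.38 log units; beyond the scatter) is the largest step seen.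

Compound 4 `Cc1cccc(Nc2nccc(-c3ccco3)n2)c1` differs from compound 1 in one place: furan-2-yl in place of thiophen-2-yl on an aromatic carbon. For the measured compounds named here, none of the measured steps touches this part of the molecule; all three change the group on the other aromatic ring and leave the thiophen-2-yl in place. Going by the values given here, there is therefore no measured step that bears directly on the change from compound 1 to compound 4, and the expectation can rest only on the fact that the group leaving and the group entering are alike in size and in what is counted. Compound 4 is expected to give a number close to that of compound 1, with the step of a 1.7-fold higher number from compound 1 to compound 4 (0.22 log units; within the scatter) most likely within or just beyond the scatter, in either direction. Compound 4 is estimated at 500 nM, in a range from 150 nM to 1700 nM.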

Compound 4, half-maximal inhibitory concentration: 2100 nM
Compound 4: middle estimate off by 4.2-fold (0.62 log units), on the low side; the whole stated range lies below it.
By their numbers in this assay, from the lowest: compound 2; then compound 1; then compounds 4 and 3 (each within the scatter of the next).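

In this assay, for the compounds shown here, the change of thiophen-2-yl to furan-2-yl gives a 7.0-fold higher number from compound 1 to compound 4 (0.85 log units; beyond the scatter) and so shows that this position, next to the ring nitrogen and untouched by the earlier steps, is not indifferent to the group it carries. The two groups have the same counts of heavy atoms and hydrogen-bond acceptors and differ only in sulfur against oxygen, so among these compounds matching counts did not keep the number in place. No measurement shown accounts for this step.

From the compounds shown here alone, whether a phenyl ring or a simple amine at this position would stand nearer to compound 1 or to compound 4 remains open. Also open, going by these compounds, is whether furan-2-yl would bring a step of similar size to compound 2, which carries 2-(1H-imidazol-1-yl)ethoxy.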